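A few compounds are considered here, and "the series" means these few. Any claim that something is new, unique, unknown or untested is made for them only; others in the source may bear on it.

Compound 3 `O[C@@H](c1ccccc1)[C@H]1CO[C@H](c2ccccc2)[C@@H](C/C=C/c2cccc(F)c2)C1` gives 8380 nM in a functional assay on HeLa cells (Homo sapiens) for cytotoxicity, read by WST assay, with a stated time of 48 h (on this read-out higher numbers stand for weaker inhibition and lower numbers for stronger inhibition), the lowest of the three numbers in hand. Compound 1 `O[C@@H](c1ccccc1)[C@H]1CO[C@H](c2ccccc2)[C@@H](C/C=C/c2ccccn2)C1` gives 33800 nM and compound 2 `Oc1cccc(/C=C/C[C@H]2C[C@@H]([C@@H](O)c3ccccc3)CO[C@@H]2c2ccccc2)c1` gives 18600 nM. The steps of a 4.0-fold lower number from compound 1 to compound 3 (0.61 log units; beyond the scatter) and a 2.2-fold lower number from compound 2 to compound 3 (0.35 log units; beyond the scatter) show that the group on the double-bonded chain carbon moves the read-out modestly, while a 1.8-fold lower number from compound 1 to compound 2 (0.26 log units; within the scatter) stays within the scatter. Compound 4 `C=CC[C@H]1C[C@@H]([C@@H](O)c2ccccc2)CO[C@@H]1c1ccccc1` differs from compound 3 by vinyl in place of 2-(3-fluorophenyl)ethenyl on a saturated chain carbon bound to a saturated ring carbon. Going by the values given here, no measured step removes the aromatic ring from this chain, so the steps in hand bear only indirectly; they do indicate that this end of the molecule matters. Compound 4 is expected to give a higher number, estimated at 30000 nM with a range of 12000 nM to 80000 nM. The expected step is a 3.6-fold higher number from compound 3 to compound 4 (0.55 log units; beyond the scatter), beyond the scatter.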

Compound 4, half-maximal inhibitory concentration: 25400 nM
Estimate against measurement, compound 4: 1.2-fold (0.07 log units) above; the measured number falls inside the stated range.
By their numbers in this assay, from the lowest: compound 3; then compounds 2, 4 and 1 (each within the scatter of the next).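

Replacing the aryl end with vinyl gives (a 3.0-fold higher number from compound 3 to compound 4 (0.48 log units; beyond the scatter)) in this assay, so at this position 2-(3-fluorophenyl)ethenyl separates from vinyl. The same replacement stays within the scatter for the other two chains, with (a 1.4-fold higher number from compound 2 to compound 4 (0.14 log units; within the scatter)) and (a 1.3-fold lower number from compound 1 to compound 4 (0.12 log units; within the scatter)), so an aromatic ring on this chain does not by itself lower the number. No measured evidence gives a reason for this difference among the three aryl groups.

Still open, from the compounds shown here alone, is whether an amine or a carboxylic acid on that aromatic ring would lower the number further. Also open, going by these compounds, is how a longer saturated chain without a ring would compare with allyl.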